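Removing two fluorines from an aryl ether side chain

A few compounds are considered here, and "the series" means these few. Any claim that something is new, unique, unknown or untested is made for them only; others in the source may bear on it.

Measured so far:
- compound 1, `O=C(O)Cn1nc(Cc2nc3cc(Cl)c(OCC(F)F)cc3[nH]2)c2ccccc2c1=O`: < 56.7 mL/min/kg
- compound 2, `C[C@@H](C(=O)O)c1nn(Cc2cn3cc(OCC4CC4)c(Cl)cc3n2)c2ccccc2c1=O`: < 55 mL/min/kg
- compound 3, `O=C(Cc1nn(C2CC2)c(=O)c2ccccc12)Nc1ccc(OC(F)(F)F)c(Cl)c1`: 2300 mL/min/kg

In an ADME assay on microsomes from liver (Mus musculus) for metabolic stability (a higher number here means faster removal of the compound, a lower number slower removal), compound 1 gives < 56.7 mL/min/kg, which is a limit of the assay rather than a number. Compound 2 also sits at a limit, < 55 mL/min/kg, as the limit of < 55 mL/min/kg in this assay, at which 1 of the 3 values shown sits, shows. Compound 3 gives a real number, 2300 mL/min/kg. So compound 1 stands at the slow end of what this assay can report, together with compound 2 at the limit of < 56.7 mL/min/kg in this assay, at which 1 of the 3 values shown sits, while compound 3 is cleared much faster.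

Compound 4, `CCOc1cc2[nH]c(Cc3nn(CC(=O)O)c(=O)c4ccccc34)nc2cc1Cl`, has not yet been measured. It differs from compound 1 in one place: methyl in place of difluoromethyl on a saturated chain carbon bound to an oxygen on an aromatic ring. Among the compounds with values here, no measured pair shows this change, so its effect in this assay is unknown from these data.

The step from compound 1 to compound 4 is expected to be a moderate rise, beyond the usual scatter: an at least 1.4-fold higher number from compound 1 to compound 4 (0.14 log units; that floor lies within the scatter). Compound 4 is expected to give about 80 mL/min/kg, somewhere between 30 mL/min/kg and 250 mL/min/kg.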

Compound 4, clearance: < 51.7 mL/min/kg
Compound 4: a limit, no number; the forecaster's own chance of this, stated with the estimate: 40%; at least 1.5-fold (0.18 log units) between middle value and limit.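

In this assay, compound 1 and compound 4 both sit at a limit of the assay rather than at a number, so no step can be read between them. The compounds shown leave open whether replacing difluoromethyl with methyl changes clearance at all, and in which direction.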